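Sulfonamide series: methoxy in place of pyrrolidin-1-yl

This account rests on a few compounds, and the source may have more. Where it says the series, first, only, none or still open, it means among the compounds named here.

Among the compounds with values here, compound 2 `Cc1ccc(S(=O)(=O)Nc2ccc(-c3ccccc3N3CCCC3)nn2)cc1` gives 1.7 nM in an assay on mitochondria from liver for inhibition of kynurenine 3-monooxygenase (Mus musculus), read by LC-MS, with stated times of 5 min and 30 min (a higher number here means a weaker inhibitor, a lower number a stronger inhibitor), the lowest of the two numbers so far. Compound 1 `CN(C)c1ccccc1S(=O)(=O)Nc1ccc(-c2cccc(Cl)c2)nn1` gives 118 nM in this assay, and the gap between the two lies beyond the scatter. Within the data shown here, no measured pair differs in one place, so no step size has been observed. Compound 3 `COc1ccccc1-c1ccc(NS(=O)(=O)c2ccc(C)cc2)nn1` carries the change (methoxy in place of pyrrolidin-1-yl on an aromatic carbon). This change is expected to raise the number, and the step of a 5.9-fold higher number from compound 2 to compound 3 (0.77 log units; beyond the scatter) is estimated as moderate and beyond the scatter. Compound 3 is estimated at 10 nM, within 2.5 nM to 40 nM.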

Compound 3, half-maximal inhibitory concentration: 36.5 nM
Compound 3: middle estimate off by 3.7-fold (0.56 log units), on the low side; measured number inside the range.
By their numbers in this assay, from the lowest: compound 2; then compound 3; then compound 1.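

Methoxy in place of pyrrolidin-1-yl on this aromatic carbon, ortho to a large group, gives the first one-place step in the series: a 21-fold higher number from compound 2 to compound 3 (1.33 log units; beyond the scatter) in this assay. The number at this position therefore depends strongly on the group it carries, and the pyrrolidin-1-yl of compound 2 is clearly preferred over methoxy. Nothing at hand bears on the reason for this step.

As far as these compounds go, whether a piperidine ring or an ethoxy group on this carbon would hold the number near that of compound 2 remains open. Also open, from the compounds shown here alone, is whether the step keeps its size with a different sulfonamide part.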